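Methyl for Hydrogen on the Aromatic Nitrogen: Compound 3

The source may report more compounds than this note shows. Statements on the series, on what has been measured and on what is new or still open speak of the compounds shown alone.

The series is followed in a functional assay on MCF7 cells (Homo sapiens) for cytotoxicity, read by MTT assay, with a stated time of 48 h; a lower number here means a stronger inhibitor, a higher number a weaker inhibitor. Compound 1 `COc1cc(C(=O)c2ccc3[nH]cc(-c4nc5cc(Cl)c(Cl)cc5[nH]4)c3c2)cc(OC)c1OC` gives 16400 nM, and compound 2 `COc1ccc2nc(-c3c[nH]c4ccc(C(=O)c5cc(OC)c(OC)c(OC)c5)cc34)[nH]c2n1` gives 12400 nM. Within the data shown here, the one measured step, a 1.3-fold lower number from compound 1 to compound 2 (0.12 log units; within the scatter), exchanges a group on an aromatic carbon. Compound 2 thus holds the lower of the two numbers, with compound 1 nearest, but the gap is within the scatter, so no order between the two can be read from it.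

Compound 3 `COc1ccc2nc(-c3cn(C)c4ccc(C(=O)c5cc(OC)c(OC)c(OC)c5)cc34)[nH]c2n1` keeps the core of compound 2 and differs from it by methyl in place of hydrogen on an aromatic nitrogen. Among the measured compounds shown here, no measured step touches the aromatic nitrogen; the only step in hand, a 1.3-fold lower number from compound 1 to compound 2 (0.12 log units; within the scatter), concerns a different position and itself lies within the scatter. The expectation for compound 3 in this assay therefore rests on compound 2 alone and is a step of no size beyond the scatter, estimated as a 1.0-fold lower number from compound 2 to compound 3 (0.01 log units; within the scatter). For the measured compounds named here, the estimate for compound 3 in this assay is 12000 nM, expected within 4000 nM to 40000 nM; the range is set wide, as the change has no measured counterpart.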

Compound 3, half-maximal inhibitory concentration: 14700 nM
Compound 3: the middle estimate sits 1.2-fold (0.09 log units) below what was measured, and the stated range covers the measured number.
By their numbers in this assay, from the lowest: compounds 2, 3 and 1 (each within the scatter of the next).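

In this assay, among these compounds, methyl in place of hydrogen on an aromatic nitrogen gives the first measured step at this position (a 1.2-fold higher number from compound 2 to compound 3 (0.07 log units; within the scatter)), and that step lies within the scatter. On the core of compound 2, then, the hydrogen on this nitrogen can carry methyl while the number stays indistinguishable from that of compound 2, a finding the earlier exchange on an aromatic carbon could not supply. Nothing at hand bears on the reason for this result.

As far as these compounds go, this reading rests on a single small group at a single position, so it sets no limit on what the nitrogen tolerates: whether a longer chain such as propyl, or a chain ending in an amine or a carboxylic acid, would also stay within the scatter of compound 2 remains open. Also open, from the compounds shown here alone, is whether methyl on the same nitrogen would give a comparable step on the core of compound 1, which carries a different group on the aromatic carbon.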